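This account rests on a few compounds, and the source may have more. Where it says the series, first, only, none or still open, it means among the compounds named here.

Measured so far:
Compound 1 `O=c1cc(CSC(=S)N2CCCCC2)oc2cc(Cl)ccc12` gives 13800 nM in a functional assay on LM7 cells (Homo sapiens) for antiproliferative activity, read by MTT assay, with a stated time of 72 h; a lower number here means a stronger inhibitor, a higher number a weaker inhibitor.
Compound 2 `O=c1cc(CSC(=S)N2CCCCC2)oc2ccccc12` gives > 25000 nM in this assay, which is a limit of the assay rather than a number.

For the measured compounds named here, compound 1 therefore stands as the only compound with an actual number in this assay; the one further value shown is a limit. Going by the values given here, the single measured step, an at least 1.8-fold higher number from compound 1 to compound 2 (0.25 log units; that floor lies within the scatter), puts hydrogen in place of chloro on an aromatic carbon, and its floor rests on (the limit of > 25000 nM in this assay, at which 1 of the 2 values shown sits).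

Compound 3 `O=c1cc(CSC(=S)N2CCCC2)oc2cc(Cl)ccc12` differs from compound 1 at another place: pyrrolidin-1-yl in place of piperidin-1-yl on a thiocarbonyl carbon. The measured step changes an aromatic carbon, not the thiocarbonyl carbon, so it gives no direct guide to this change. Among the compounds with values here, no measured pair alters the ring that sits on the thiocarbonyl carbon. With no guide of that kind, the expectation in this assay is a step no larger than the usual scatter, in either direction. Compound 3 is accordingly estimated at 13800 nM, with an expected range from 5500 nM to 32000 nM. The expected step of no change at the digits printed from compound 1 to compound 3 (within the scatter) is thus a small one.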

Compound 3, half-maximal inhibitory concentration: > 25000 nM
Compound 3 was reported as a limit; the forecaster's own chance of this, stated with the estimate: 25%; middle value at least 1.8-fold (0.25 log units) away from the limit.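

Changing the ring on the thiocarbonyl carbon is new here: pyrrolidin-1-yl in place of piperidin-1-yl gives an at least 1.8-fold higher number from compound 1 to compound 3 (0.25 log units; that floor lies within the scatter). For the compounds shown here, the result for compound 3 is a limit of the assay and not a number, so the real size of this step cannot be read, and it may turn out small or large: the limit of > 25000 nM in this assay, at which 2 of the 3 values shown sit. In this assay compound 1 is still the only compound with an actual number, and this position now joins the chloro on the aromatic carbon as a place where a single change from compound 1 ends at the limit.

The compounds shown leave open whether any other group on the thiocarbonyl carbon, such as a morpholine ring, a seven-membered azepane ring or an open-chain diethylamino group, would give a lower number than compound 1. They also leave open whether fluoro or bromo in place of chloro on the aromatic carbon would keep a measurable number in this test of cell growth.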